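A Thiophene Ring Replaces a Hydroxyphenyl Group

The source may hold more compounds than are shown below. What is called first, only, known or untested is meant among the compounds shown, and "the series" means these compounds.

Three compounds have been measured in a functional assay on HT-29 cells (Homo sapiens) for inhibition, read by MTT assay, with a stated time of 48 h; a lower number here means a stronger inhibitor, a higher number a weaker inhibitor:

- compound 1, `COc1cc(-c2cc(-c3ccc(N)cc3)nc(-c3ccccc3)n2)cc(OC)c1OC`, gives > 25000 nM, which is a limit of the assay.
- compound 2, `COc1cc(-c2cc(-c3ccccc3)nc(-c3ccccc3)n2)cc(OC)c1OC`, gives 7930 nM.
- compound 3, `COc1cc(-c2cc(-c3cccc(O)c3)nc(-c3ccccc3)n2)cc(OC)c1OC`, gives > 25000 nM, which is a limit of the assay.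

Compound 3 thus stands at the limit, and one further value sits there as well, (the limit of > 25000 nM in this assay, at which 2 of the 3 values shown sit); only compound 2 has a number. Compound 4, `COc1cc(-c2cc(-c3cccs3)nc(-c3ccccc3)n2)cc(OC)c1OC`, has not yet been measured. It differs from compound 3 in one place: thiophen-2-yl in place of 3-hydroxyphenyl on an aromatic carbon. The measured step that bears on this change is an at least 3.1-fold higher number from compound 2 to compound 3 (0.49 log units; beyond the scatter), in which the arrival of the hydroxy group carried the value out to the limit. Compound 4 carries no hydroxy group, and the entering thiophen-2-yl ring has 0 hydrogen-bond donors, which places it nearer to compound 2 than to compound 3. Since the hydroxy step was at least modest, the step back is expected to be at least modest as well, toward a lower number, so that an at least 2.5-fold lower number from compound 3 to compound 4 (0.39 log units; beyond the scatter) is the expected step. For compound 4 the estimate is 10000 nM, within 3000 nM to 30000 nM.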

Compound 4, half-maximal inhibitory concentration: > 25000 nM
Compound 4 ended at the assay's limit (the forecaster's own chance of this, stated with the estimate: 35%); middle value at least 2.5-fold (0.39 log units) away from the limit.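

Compound 3 had tied the loss of a measurable value to the arrival of the hydroxy group, but thiophen-2-yl, with 0 hydrogen-bond donors, does not keep that value: in this assay, thiophen-2-yl in place of phenyl gives an at least 3.1-fold higher number from compound 2 to compound 4 (0.49 log units; beyond the scatter). A hydrogen-bond donor on this ring is therefore not required for a compound to reach the limit, where most of the set now sits: the limit of > 25000 nM in this assay, at which 3 of the 4 values shown sit. The steps linking compound 4 to compound 1 and to compound 3 cannot be read, since each joins two limits.

Within the data shown here, compound 2 remains the only compound here with a number, so it is still open whether any group at this position can give a lower one. A methyl group, a chlorine atom or a carboxylic acid on the phenyl ring could help to test this.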